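Methoxy added to a hydroxyindole ketone

The compounds below may be only part of what the source reports. "The series", "measured", "known", "first", "only" and "open" are said of these compounds alone.

The series rests on a shared core, seen in compound 1 `O=C(Cc1cccnc1)c1cc2c(O)cccc2[nH]1`, which carries a hydroxy group on its six-membered ring. Within the data shown here, in an in vitro assay on P815B cells for inhibition of Indoleamine 2,3-dioxygenase 1 (Mus musculus), tested at 20 uM (a higher number here means more inhibition at the concentration tested (going by the name of the read-out), a lower number less inhibition), compound 1 gives "not active" (no number reported), so no single number stands for it; the only number in the set comes from compound 2 `O=C(Cc1cccnc1)c1cc2ccccc2[nH]1`, which lacks the hydroxy group and gives 13% in this assay. Compound 3 `Cn1c(C(=O)Cc2cccnc2)cc2ccccc21`, with a methyl on the ring nitrogen, gives "not active" (no number reported) in this assay. Among the measured compounds shown here, no pair of these differs in a single place, so no step between measured compounds can be stated, and compound 1 stands among the entries without a number.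

Compound 4 `COc1ccc2[nH]c(C(=O)Cc3cccnc3)cc2c1O` arises from compound 1 by the change (methoxy in place of hydrogen on an aromatic carbon). For the measured compounds named here, nothing measured speaks to a methoxy group in this position, and the sole number in the set is small. The step from compound 1 to compound 4 is therefore expected to be none beyond the scatter of this assay, in either direction. Compound 4 is estimated to give 8% in this assay, within a range from 0% to 25%.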

Compound 4, a percentage reported as inhibition, at one concentration (the size of the read-out at that concentration, not a potency): 11%
Compound 4: middle estimate off by 3 percentage points, on the low side; measured number inside the range.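

Among these compounds, compound 1 gives "not active" (no number reported) in this assay while compound 4 gives 11%, and with a number on only one side, no step between compound 1 and compound 4 can be read. Nothing at hand offers a reason for the result of compound 4. The compounds shown leave open whether the methoxy group alters inhibition at all.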